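The source may hold more compounds than are shown below. What is called first, only, known or untested is meant among the compounds shown, and "the series" means these compounds.

Working notes on the series. Compound 2 `OC1CCCCC1n1cc(CN2CCN(c3ccccc3)CC2)nn1` in an assay on nucleic acid for inhibition of Nucleic Acid, read by fluorescence, tested at 100 uM (a higher number here means more inhibition at the concentration tested (going by the name of the read-out), a lower number less inhibition), gives 47%. Compound 3 `CCCCC(O)Cn1cc(CN2CCN(c3ccccc3)CC2)nn1` gives 47% there, and compound 1 `CCCCNC(=O)OCC(O)Cn1cc(CN2CCCC(C(=O)OCC)C2)nn1` gives 24%. Compound 2 thus stands level with compound 3 at the digits given, the pair forming the highest numbers of the three, while compound 1 lies below them beyond the scatter. Within the data shown here, the one single-point step measured so far, no change at the digits printed from compound 2 to compound 3 (within the scatter), puts 2-hydroxyhexyl in place of 2-hydroxycyclohexyl on an aromatic nitrogen and leaves the number where it was.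

Compound 4 `O=C(OC1CCCCC1n1cc(CN2CCN(c3ccccc3)CC2)nn1)c1ccccc1` is the next member to be tested. Relative to compound 2 the change is benzoyl in place of hydrogen on an oxygen on a saturated carbon: hydroxy becomes benzoyloxy, the benzoyl entering on an oxygen on a saturated carbon whose other neighbour is a saturated ring carbon. Among the measured compounds shown here, no measured step touches this oxygen; no change at the digits printed from compound 2 to compound 3 (within the scatter) concerns only the carbon group that carries the hydroxy, and its size fell within the scatter. The benzoyl change is therefore without direct precedent in this set and the expectation is cautious: for compound 4 a step of a number 2 percentage points lower from compound 2 to compound 4 (within the scatter) is expected, that is, none beyond the scatter, with wide uncertainty. The estimate for compound 4 is 45%, between 25% and 65%.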

Compound 4, a percentage reported as inhibition, at one concentration (the size of the read-out at that concentration, not a potency): 21%
Compound 4: the middle estimate sits 24 percentage points above what was measured; the measured number lies below the stated range.
By their numbers in this assay, from the lowest: compounds 4 and 1 (each within the scatter of the next); then compounds 2 and 3 (each within the scatter of the next).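

The oxygen on a saturated carbon whose other neighbour is a saturated ring carbon proves sensitive in this assay: benzoyl in place of hydrogen there gives a number 26 percentage points lower from compound 2 to compound 4 (beyond the scatter) in this series. Among these compounds, the earlier step, which altered only the carbon group carrying the hydroxy, gave no change at the digits printed from compound 2 to compound 3 (within the scatter) and so left this oxygen untested; hydroxy to benzoyloxy is the first change with the rest of the structure held constant to move the number beyond the scatter. Nothing measured here bears on why the number falls.

Going by these compounds, whether the fall follows from the benzoyl itself, with its six-membered aromatic ring, or from any group replacing the hydrogen on this oxygen remains open, and acetyl or methyl on the same oxygen would separate these two readings. Also open, on these data alone, is whether the same change gives a comparable step on the 2-hydroxyhexyl group of compound 3, which would show whether the result extends beyond the 2-hydroxycyclohexyl compounds.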